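Piperidin-1-yl for morpholin-4-yl at the assay limit

The source may hold more compounds than are shown below. What is called first, only, known or untested is meant among the compounds shown, and "the series" means these compounds.

Of the compounds shown here, three built on one shared core have been tested in a functional assay on MDA-MB-231 cells (Homo sapiens) for inhibition, read by MTT assay, with a stated time of 48 h; on this read-out higher numbers stand for weaker inhibition and lower numbers for stronger inhibition. There compound 1 `Cn1c(/C=C2\SC(=O)N(CC(=O)Nc3cc(C(C)(C)C)on3)C2=O)nc2ccccc21` gives 33800 nM. Compound 3 `Cn1c(/C=C2\SC(=O)N(CC(=O)N3CCOCC3)C2=O)nc2ccccc21` reads > 50000 nM, which is a limit of the assay and not a number. Compound 3 therefore stands at the limit of > 50000 nM in this assay, at which 2 of the 3 values shown sit.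

Compound 4 `Cn1c(/C=C2\SC(=O)N(CC(=O)N3CCCCC3)C2=O)nc2ccccc21` differs from it in one place: piperidin-1-yl in place of morpholin-4-yl on a carbonyl carbon. In words, piperidin-1-yl stands in place of morpholin-4-yl on a carbonyl carbon. For the measured compounds named here, the only measured step at this place is an at least 1.4-fold higher number from compound 1 to compound 3 (0.17 log units; that floor lies within the scatter), and it involves a different group, so it says little about this swap. Compound 2 `CCn1c(/C=C2\SC(=O)N(CC(=O)N3CCCCC3)C2=O)nc2ccccc21` already carries piperidin-1-yl there, though its core is not identical, and it reads > 50000 nM, again a limit.

On that reading of compound 2, no step beyond the scatter is expected in this assay, and the estimated step is a number no higher from compound 3 to compound 4 (the limit leaves the size open). Compound 4 is expected to lie near 50000 nM, with an estimated range of 28000 nM to 90000 nM.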

Compound 4, half-maximal inhibitory concentration: > 50000 nM
Compound 4: a limit, no number; the forecaster's own chance of this, stated with the estimate: 75%; the middle value lies on the limit itself.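

Piperidin-1-yl on this carbonyl carbon gives no readable value in this assay, so the hydrogen-bond acceptor counted on morpholin-4-yl but not on piperidin-1-yl cannot be tied to any measured change. The steps between compound 3 and compound 4 and between compound 2 and compound 4 cannot be read, as both ends of each are limits, and the position now stands as follows: the limit of > 50000 nM in this assay, at which 3 of the 4 values shown sit. For the compounds shown here, the one readable step, an at least 1.4-fold higher number from compound 1 to compound 4 (0.17 log units; that floor lies within the scatter), gives only a floor, so it does not set the (5-(tert-butyl)-1,2-oxazol-3-yl)amino group apart from piperidin-1-yl.

The compounds shown leave open how far the true values of compound 2, compound 3 and compound 4 lie past the limit. They also leave open what a phenylamino or 4-methylpiperazin-1-yl group would read on the same carbonyl carbon.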